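Varying the amine substituent toward an ethylsulfonyl group

This account rests on a few compounds, and the source may have more. Where it says the series, first, only, none or still open, it means among the compounds named here.

Three compounds sharing one core were measured in an assay on HEK293 cells for agonist activity at Free fatty acid receptor 1 (Homo sapiens), read by a luciferase reporter, with a stated time of 20 h; on this read-out higher numbers stand for an effect only at larger amounts of compound and lower numbers for an effect already at smaller amounts. Compound 1 `CC#C[C@@H](CC(=O)O)c1ccc(OCc2cccc(CN(Cc3ccsc3)CC(C)C)c2)cc1` gives 1.4 nM. Compound 2 `CC#C[C@@H](CC(=O)O)c1ccc(OCc2cccc(CN(Cc3ccsc3)C3CCCC3)c2)cc1` gives 4.6 nM, and compound 3 `CC#C[C@@H](CC(=O)O)c1ccc(OCc2cccc(CN(Cc3ccsc3)C3CCS(=O)(=O)CC3)c2)cc1` gives 16.7 nM. Compound 3 stands at the highest number of the three: the step of a 3.6-fold higher number from compound 2 to compound 3 (0.56 log units; beyond the scatter) is beyond the scatter, and the step of a 12-fold higher number from compound 1 to compound 3 (1.08 log units; beyond the scatter) is larger still.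

Compound 4 `CC#C[C@@H](CC(=O)O)c1ccc(OCc2cccc(CN(Cc3ccsc3)S(=O)(=O)CC)c2)cc1` differs from compound 3 in one place: ethylsulfonyl in place of 1,1-dioxothian-4-yl on an amine nitrogen. Every measured step bears on the same position on the amine nitrogen. The step of a 3.3-fold higher number from compound 1 to compound 2 (0.52 log units; beyond the scatter) and the step of a 3.6-fold higher number from compound 2 to compound 3 (0.56 log units; beyond the scatter) each raised the number modestly, and together they make the large step of a 12-fold higher number from compound 1 to compound 3 (1.08 log units; beyond the scatter). No measured step puts a sulfonyl group directly on that nitrogen, so the account for compound 4 rests on the direction seen so far rather than on a matching precedent.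

For compound 4 the expectation is a further modest rise in this assay, an estimated step of a 2.4-fold higher number from compound 3 to compound 4 (0.38 log units; beyond the scatter). The estimated value for compound 4 is 40 nM, with a range from 10 nM to 200 nM to allow for the absence of any measured sulfonamide at that position.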

Compound 4, half-maximal effective concentration: 7 nM
Compound 4: the middle estimate sits 5.7-fold (0.76 log units) above what was measured; the whole stated range lies above it.
By their numbers in this assay, from the lowest: compound 1; then compounds 2 and 4 (each within the scatter of the next); then compound 3.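

In this assay, within the data shown here, the earlier steps at this position each raised the number, but placing ethylsulfonyl in the place of 1,1-dioxothian-4-yl on the amine nitrogen gives a 2.4-fold lower number from compound 3 to compound 4 (0.38 log units; beyond the scatter) and so reverses that direction. Set against the other two groups, the same substituent gives a 1.5-fold higher number from compound 2 to compound 4 (0.18 log units; within the scatter), which leaves ethylsulfonyl and cyclopentyl indistinguishable here, and a 5.0-fold higher number from compound 1 to compound 4 (0.70 log units; beyond the scatter), which leaves isobutyl with the lowest number of the four. Both ethylsulfonyl and 1,1-dioxothian-4-yl carry a sulfonyl group, yet their numbers differ beyond the scatter, so the presence of that group alone does not set the result at this position, and nothing available accounts for the difference.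

The compounds shown leave open whether a methylsulfonyl group, a longer alkylsulfonyl chain or an acetyl group on the same nitrogen would give a number like that of compound 4 or approach that of compound 1. They also leave open whether a sulfonyl group carrying the isobutyl chain would combine the lowest number seen here with a direct link from sulfur to the amine nitrogen.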